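The source may report more compounds than this note shows. Statements on the series, on what has been measured and on what is new or still open speak of the compounds shown alone.

Measured so far:
compound 1 `Cc1nc(-c2cccs2)sc1COc1ccc2c(c1)OCC2CC(=O)O`: "not determined" (no result reported)
compound 2 `Cc1nc(-c2cc3ccccc3o2)sc1COc1ccc2c(c1)OCC2CC(=O)O`: "not determined" (no result reported)
compound 3 `Cc1cccc(-c2nc(C)c(COc3ccc4c(c3)OCC4CC(=O)O)s2)c1`: 119 nM

In a functional assay on CHO cells for agonist activity at Free fatty acid receptor 1 (Homo sapiens), read by FLIPR and calcium flux (a lower number here means that less compound is needed, a higher number that more compound is needed for the effect), compound 3 gives 119 nM. Compound 1 and compound 2 carry no number in this assay, so compound 3 stands alone and cannot be ranked against anything. Compound 4 `Cc1nc(-c2cccc(Cl)c2)sc1COc1ccc2c(c1)OCC2CC(=O)O` differs from compound 3 by chloro in place of methyl on an aromatic carbon. Among the compounds with values here, no pair of measured compounds shows a comparable single change, so the size of this step has no measured precedent here. The expectation is a small shift, if any: the estimated step of a 1.2-fold lower number from compound 3 to compound 4 (0.08 log units; within the scatter) stays within the usual scatter of repeated measurements. Compound 4 is accordingly expected at 100 nM in this assay, with a plausible range from 40 nM to 250 nM.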

Compound 4, half-maximal effective concentration: 138 nM
The estimate for compound 4 lay 1.4-fold (0.14 log units) below the measured number, and the stated range covers the measured number.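

With methyl and chloro exchanged on the aromatic carbon, this assay gives a 1.2-fold higher number from compound 3 to compound 4 (0.06 log units; within the scatter). Within the data shown here, this is the first measured pair, and it shows that 3-methylphenyl and 3-chlorophenyl cannot be told apart in this read-out. No measurement shown here bears on why these two groups match.

As far as these compounds go, whether this position would tolerate a group of another kind, such as an amine, a methoxy or a carboxylic acid, stays open. One pair also cannot show whether the match holds with other groups elsewhere on the shared core.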